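Compound 3 to compound 4: ethoxy for dimethylamino

The source may hold more compounds than are shown below. What is called first, only, known or untested is meant among the compounds shown, and "the series" means these compounds.

Compound 3 `CCCn1c(=O)n(C)c(=O)c2c1ncn2CCN(C)C` gives no number in a functional assay (trachea) with Cavia porcellus as the target (on this read-out higher numbers stand for an effect only at larger amounts of compound and lower numbers for an effect already at smaller amounts), and reports only a limit of > 100000 nM in that test. Compound 3 thus stands at the limit of > 100000 nM in this assay, at which 1 of the 3 values shown sits, and has no measured number to compare. Compound 1 `CCCn1c(=O)n(CC(C)=O)c(=O)c2[nH]cnc21` gives 14900 nM in this assay and compound 2 `C=CCCn1cnc2c1c(=O)n(C)c(=O)n2CCC` gives 16800 nM on the same read-out.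

The next structure, compound 4 `CCCn1c(=O)n(C)c(=O)c2c1ncn2CCOCC`, puts ethoxy in place of dimethylamino on a saturated chain carbon, two bonds along the chain from an aromatic nitrogen. Among the measured compounds shown here, only one measured step bears on this change, namely an at least 5.9-fold higher number from compound 2 to compound 3 (0.77 log units; beyond the scatter) with dimethylamino in place of vinyl at that same place. Compound 4 gives up the dimethylamino that entered in an at least 5.9-fold higher number from compound 2 to compound 3 (0.77 log units; beyond the scatter) and so a step back towards lower numbers is expected, of similar size or larger. Ethoxy is not vinyl, so the parallel with compound 2 is only loose, and a limit again cannot be excluded. The expected change is an at least 5.0-fold lower number from compound 3 to compound 4 (0.69 log units; beyond the scatter) in this assay as estimated here. For compound 4 the estimated value is 20000 nM with a range from 6000 nM to 70000 nM as its expected span.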

Compound 4, half-maximal effective concentration: 4600 nM
Compound 4: middle estimate off by 4.3-fold (0.64 log units), on the high side; measured number below the stated range.
By their numbers in this assay, from the lowest: compound 4; then compounds 1 and 2 (each within the scatter of the next). At a limit, above all of these: compound 3.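

With ethoxy in place of dimethylamino on a saturated chain carbon, two bonds along the chain from an aromatic nitrogen, this assay shows an at least 21-fold lower number from compound 3 to compound 4 (1.33 log units; beyond the scatter), so two groups that match in heavy-atom count, donors and acceptors can still lie far apart at this place. The earlier compounds had shown only a rise in the number at this place, whereas ethoxy in place of vinyl gives a 3.7-fold lower number from compound 2 to compound 4 (0.56 log units; beyond the scatter), the first change here that moves the number down, and by more than the scatter. The step from the dimethylamino compound still has only one measured end, as compound 3 gives a limit and not a number: the limit of > 100000 nM in this assay, at which 1 of the 4 values shown sits.

The compounds shown do not tell whether the gain belongs to the ether oxygen itself or to the ethyl group behind it, and a hydroxyl, a methoxy or a longer ether chain at the same place would separate the two. Nor do they show whether dimethylamino stands for amines in general, which a primary amine or a morpholine on the same chain would test, or how a carboxylic acid would fare there.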